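Benzylthio oxadiazole series: cytotoxicity notes toward compound 4

The source may hold more compounds than are shown below. What is called first, only, known or untested is meant among the compounds shown, and "the series" means these compounds.

Measured so far:
- compound 1, `COc1cc(-c2nnc(SCc3cccc(Br)c3)o2)ccc1O`: 382000 nM
- compound 2, `COc1cc(-c2nnc(SCc3ccc(C)cc3)o2)ccc1O`: 549000 nM
- compound 3, `COc1cc(-c2nnc(SCc3cccc(Cl)c3)o2)ccc1O`: 470000 nM

All three share one core and differ only in the aryl group on the saturated chain carbon bound to a sulfur. In an ADME assay on cells (Mus musculus, strain BALB/c) for cytotoxicity, read by MTT assay, with a stated time of 24 h (on this read-out lower numbers stand for higher toxicity in this test and higher numbers for lower toxicity in this test), compound 3 stands second highest of the three numbers; its nearest neighbour is compound 2 and its furthest is compound 1, and neither gap exceeds the scatter. The two steps into compound 3 both sit inside the scatter: a 1.2-fold higher number from compound 1 to compound 3 (0.09 log units; within the scatter) and a 1.2-fold lower number from compound 2 to compound 3 (0.07 log units; within the scatter). The third step, a 1.4-fold higher number from compound 1 to compound 2 (0.16 log units; within the scatter), is likewise within the scatter. On this read-out the series is flat so far.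

Compound 4, `COc1cc(-c2nnc(SCc3ccccc3)o2)ccc1O`, is not yet measured. It differs from compound 3 by hydrogen in place of chloro on an aromatic carbon. Among the compounds with values here, the steps that bear on this change are the aryl swaps already seen: bromo to chloro and 3-chlorophenyl to 4-methylphenyl, each too small to register. No shown step supports a move beyond the scatter for a further change on the same aryl ring.

For compound 4 the expected value in this assay is therefore 480000 nM, with a range from 250000 nM to 950000 nM. The expected step is a 1.0-fold higher number from compound 3 to compound 4 (0.01 log units; within the scatter), which means essentially no change.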

Compound 4, half-maximal cytotoxic concentration: 211000 nM
For compound 4 the middle estimate is 2.3-fold (0.36 log units) above the measured one; measured number outside the range, below it.
By their numbers in this assay, from the lowest: compounds 4, 1, 3 and 2 (each within the scatter of the next, the first and the last beyond it).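

Working notes after compound 4: in this assay the aryl group stayed flat while one ring substituent replaced another, but phenyl itself gives the only steps beyond the scatter so far, with a 2.2-fold lower number from compound 3 to compound 4 (0.35 log units; beyond the scatter) and a 2.6-fold lower number from compound 2 to compound 4 (0.42 log units; beyond the scatter) both modest and both pointing towards higher toxicity in this test. This does not hold as a general rule for the unsubstituted ring, since bromo goes against it: a 1.8-fold lower number from compound 1 to compound 4 (0.26 log units; within the scatter) remains inside the scatter, so compound 4 separates from the chloro and methyl compounds but not from the bromo one. Nothing available explains this difference between the substituents.

The compounds shown leave open whether the separation of compound 4 reflects the absence of any ring substituent or only the comparison with chloro and methyl, as compound 1 does not settle the matter. Also open is how this read-out responds when the same ring carries an amine, a hydroxyl or a carboxylic acid, none of which appears among these four compounds.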